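The compounds below may be only part of what the source reports. "The series", "measured", "known", "first", "only" and "open" are said of these compounds alone.

Of the compounds shown here, three have so far been tested in a functional assay on HeLa cells (Homo sapiens) for antiproliferative activity, read by MTT assay, with a stated time of 48 h; on this read-out higher numbers stand for weaker inhibition and lower numbers for stronger inhibition. Compound 1 `CN(C)CCn1c(N)c(-c2nc3ccccc3[nH]2)c2nc(C#N)c(C#N)nc21` gives 8880 nM. Compound 2 `CN(C)CCCn1c(N)c(-c2nc3ccccc3[nH]2)c2nc(C#N)c(C#N)nc21` carries the change (dimethylamino)methyl in place of dimethylamino on a saturated chain carbon, two bonds along the chain from an aromatic nitrogen and gives 25900 nM; that step is a 2.9-fold higher number from compound 1 to compound 2 (0.46 log units; beyond the scatter). Compound 3 `CN(C)CCCn1c(N)c(-c2nc3ccccc3s2)c2nc(C#N)c(C#N)nc21` gives 720 nM, a step of a 36-fold lower number from compound 2 to compound 3 (1.56 log units; beyond the scatter), the lowest number of the three. Compound 4 `CN(C)CCCCn1c(N)c(-c2nc3ccccc3s2)c2nc(C#N)c(C#N)nc21` is not yet measured; it differs from compound 3 by (dimethylamino)methyl in place of dimethylamino on a saturated chain carbon, three bonds along the chain from an aromatic nitrogen. For the measured compounds named here, this is the same kind of change as the one from compound 1 to compound 2, but here it sits three bonds along the chain from the aromatic nitrogen rather than two, and the difference between the two cores is not broken down here. Because the earlier step was a 2.9-fold higher number from compound 1 to compound 2 (0.46 log units; beyond the scatter), a step of similar size is expected, namely a 2.8-fold higher number from compound 3 to compound 4 (0.44 log units; beyond the scatter). Compound 4 is therefore estimated to give about 2000 nM, most likely between 700 nM and 6000 nM.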

Compound 4, half-maximal inhibitory concentration: 18700 nM
The estimate for compound 4 lay 9.4-fold (0.97 log units) below the measured number; the measured number lies above the stated range.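

Going from a 3-(dimethylamino)propyl to a 4-(dimethylamino)butyl chain gives a 26-fold higher number from compound 3 to compound 4 (1.41 log units; beyond the scatter). One added chain carbon raised the number on both cores, but the size of the rise did not carry over: the same change on two cores in this assay, a 2.9-fold higher number (0.46 log units; beyond the scatter) from compound 1 to compound 2 and a 26-fold higher number (1.41 log units; beyond the scatter) from compound 3 to compound 4, 8.9-fold (0.95 log units) apart, beyond the scatter of two such steps. The direction therefore held in these two pairs, but the two pairs differ both in 1H-benzimidazol-2-yl versus 1,3-benzothiazol-2-yl and in the starting chain length, and these data cannot separate the two differences or give a reason for the gap.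

Still open, on these data alone, is how a 4-(dimethylamino)butyl chain behaves with 1H-benzimidazol-2-yl, and a 2-(dimethylamino)ethyl chain with 1,3-benzothiazol-2-yl. Also open, as far as these compounds go, is whether a cyclic amine such as piperidine or morpholine at the chain end follows the same trend.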